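Para-Chlorophenyl in Place of Ortho-Bromophenyl on the Indole Core

A few compounds are considered here, and "the series" means these few. Any claim that something is new, unique, unknown or untested is made for them only; others in the source may bear on it.

Compound 1 `Cn1c(-c2ccccc2Br)cc2cc(CCC(=O)O)ccc21` was tested in a functional assay on CHO cells for agonist activity at Free fatty acid receptor 1 (Homo sapiens), read by a luciferase reporter, with a stated time of 24 h (on this read-out lower numbers stand for an effect already at smaller amounts and higher numbers for an effect only at larger amounts of compound), and gave only a limit: in this assay compound 1 gives > 10000 nM, so no number is known for it, and it stands at the weak end of what was measured (the limit of > 10000 nM in this assay, at which 1 of the 2 values shown sits). Compound 2 `COc1ccc(-c2cc3cc(CCC(=O)O)ccc3[nH]2)cc1` was also reported only as a limit, in this assay compound 2 gives > 25 nM, which is a limit of a different kind (the limit of > 25 nM in this assay, at which 1 of the 2 values shown sits). The two compounds differ in more than one place, so their values show only that one sits far above the other.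

Compound 3 `Cn1c(-c2ccc(Cl)cc2)cc2cc(CCC(=O)O)ccc21` is the next compound to be measured. It differs from compound 1 in one place: 4-chlorophenyl in place of 2-bromophenyl on an aromatic carbon of the shared core. Among the compounds with values here, no step between measured compounds covers this change, so its size is open. Compound 3 is expected to move toward the stronger side, with an estimated step of an at least 5.0-fold lower number from compound 1 to compound 3 (0.69 log units; beyond the scatter). For compound 3 the expected value in this assay is 2000 nM, within a range from 200 nM to 20000 nM.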

Compound 3, half-maximal effective concentration: > 10000 nM
Compound 3 was reported as a limit; the forecaster's own chance of this, stated with the estimate: 40%; middle value at least 5.0-fold (0.69 log units) away from the limit.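

In this assay compound 3 was, like compound 1, reported only as a limit, so no step can be read between compound 1 and compound 3: the limit of > 10000 nM in this assay, at which 2 of the 3 values shown sit.

The compounds shown leave open where compound 1 and compound 3 actually lie beyond that limit, and whether 4-chlorophenyl in place of 2-bromophenyl changes the read-out at all.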